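This account rests on a few compounds, and the source may have more. Where it says the series, first, only, none or still open, it means among the compounds named here.

Measured so far:
compound 1 `ClCc1ccc(Cn2cnc3c(Cl)ncnc32)cc1` 5120 nM
compound 2 `ClCc1cccc(Cn2cnc3ncnc(Cl)c32)c1` 40700 nM
compound 3 `ClCc1ccc(Cn2cnc3c(Cl)nc(Cl)nc32)cc1` 56200 nM

The read-out throughout is a functional assay on HCC 2998 cells (Homo sapiens) for cytotoxicity, read by sulforhodamine B assay, with a stated time of 48 h; a lower number here means that less compound is tolerated, a higher number that more compound is tolerated. Compound 1 and compound 2 are built from the same atoms joined differently; the difference between the two cores is not broken down here. Compound 2 stands second highest of the three numbers, its nearest neighbour being compound 3, within the scatter, and its furthest compound 1, beyond the scatter.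

One change is seen on both cores. From compound 1 to compound 3 the change is chloro in place of hydrogen on an aromatic carbon, and in this assay it gives an 11-fold higher number from compound 1 to compound 3 (1.04 log units; beyond the scatter). The unmeasured compound 4 `ClCc1cccc(Cn2cnc3nc(Cl)nc(Cl)c32)c1` carries the same change on the core of compound 2, namely (chloro in place of hydrogen on an aromatic carbon); the place is described in the same words in both cases, so this is the same change, not merely the same kind.

Going by the values given here, with only one measured instance of this change, the expectation for compound 4 rests on that single step from compound 1 to compound 3 and on the value of compound 2. Among the compounds with values here, the step from compound 2 to compound 4 is expected to be a 7.4-fold higher number from compound 2 to compound 4 (0.87 log units; beyond the scatter), of a size comparable to the step seen from compound 1 to compound 3, because an 11-fold higher number from compound 1 to compound 3 (1.04 log units; beyond the scatter) is the only guide available. Compound 4 is therefore estimated at 300000 nM in this assay, with a range from 70000 nM to 1200000 nM; since compound 2 already sits high, there is a fair chance that the assay reports only a limit for compound 4.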

Compound 4, concentration lethal to 50% of the cells: 5750 nM
Compound 4: middle estimate off by 52-fold (1.72 log units), on the high side, and the stated range ends above it.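

In this assay, chloro in place of hydrogen on an aromatic carbon gives a 7.1-fold lower number from compound 2 to compound 4 (0.85 log units; beyond the scatter), so on the core of compound 2 less compound is tolerated after the change, the reverse of what the same change does on the core of compound 1. Set side by side, the two steps run in opposite directions and the gap between them is beyond the scatter: the same change on two cores in this assay, an 11-fold higher number (1.04 log units; beyond the scatter) from compound 1 to compound 3 and a 7.1-fold lower number (0.85 log units; beyond the scatter) from compound 2 to compound 4, 78-fold (1.89 log units) apart, beyond the scatter of two such steps. Going by these compounds alone, in this series, then, the change does not carry from one core to the other as a fixed step, and even its direction depends on the core, though with a single pair on each core this shows only that the core matters, not why it does, nor which of the two steps would be the more typical on a further core.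

The compounds shown leave open whether another group on the same aromatic carbon between two ring nitrogen atoms, such as an amine or a methoxy group, would also split the two cores in this way or would move both in one direction. They also leave open whether a third core would follow compound 1 to compound 3, compound 2 to compound 4, or neither.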